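A few compounds are considered here, and "the series" means these few. Any claim that something is new, unique, unknown or untested is made for them only; others in the source may bear on it.

Compound 2, `O=C(N[C@@H]1CCCC[C@H]1O)c1cnc(OC2CCC2)c(-c2ccc(Cl)cc2)c1`, stands at the lowest of the two numbers recorded so far in an ADME assay (liver) for pharmacokinetics, with Liver microsome (Rattus norvegicus) as the target, read by LC-MS, using microsomes, tested at 2 uM; a higher number here means faster removal of the compound, a lower number slower removal. In this assay compound 2 gives 0.21 mL/min/kg. For the measured compounds named here, its nearest neighbour is compound 1, `O=C(N[C@@H]1CCCC[C@H]1O)c1cnc(Oc2ccccc2)c(-c2ccc(Cl)cc2)c1`, which in this assay gives 0.353 mL/min/kg; the one step that joins them, a 1.7-fold lower number from compound 1 to compound 2 (0.23 log units; within the scatter), involves cyclobutyl in place of phenyl on an oxygen on an aromatic ring and stays within the scatter, so the two compounds cannot be told apart on this read-out.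

Compound 3, `O=C(N[C@@H]1CCCC[C@H]1O)c1cnc(OCC2CC2)c(-c2ccc(Cl)cc2)c1`, is the next compound in line. It differs from compound 2 by cyclopropylmethyl in place of cyclobutyl on an oxygen on an aromatic ring. Going by the values given here, no measured step concerns this particular exchange; the only step available, from compound 1 to compound 2, replaces one group on the same oxygen and stays within the scatter. On this basis, and with the two groups having the same atoms joined differently, compound 3 is expected to show a step of a 1.0-fold higher number from compound 2 to compound 3 (0.02 log units; within the scatter) in this assay, that is, no move beyond the scatter. Compound 3 is therefore estimated to give 0.22 mL/min/kg in this assay, within a range from 0.11 mL/min/kg to 0.45 mL/min/kg.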

Compound 3, clearance: 0.064 mL/min/kg
Beside the measured number, compound 3's estimate is 3.4-fold (0.54 log units) above it; the whole stated range lies above it.
By their numbers in this assay, from the lowest: compound 3; then compounds 2 and 1 (each within the scatter of the next).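

The position on the oxygen on an aromatic ring can move the number in this assay: a 3.3-fold lower number from compound 2 to compound 3 (0.52 log units; beyond the scatter) with cyclopropylmethyl in place of cyclobutyl, although the earlier exchange at this oxygen stayed within the scatter. The comparison with the phenyl compound gives the same direction, a 5.5-fold lower number from compound 1 to compound 3 (0.74 log units; beyond the scatter), so compound 3 stands lowest of the three, with its steps to both others beyond the scatter, and the exchange from cyclobutyl shows that groups with the same atoms, joined differently, can be told apart here. Nothing available explains why this rearrangement changes the number.

The compounds shown leave open whether the lower number goes with the three-membered ring or with the methylene link to the oxygen, a question that a cyclopropyl group directly on the oxygen or an open isobutyl chain would address. They also leave open whether the step would persist on a different core, as all three compounds share everything outside this one substituent.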